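The source may hold more compounds than are shown below. What is called first, only, known or untested is meant among the compounds shown, and "the series" means these compounds.

Three compounds share one core and differ only at an amide-type nitrogen in the ring. Compound 1 `O=C1COCC(NC(=O)OCc2ccccc2)C(=O)N1` carries hydrogen there, and in a functional assay on the whole organism (strain ICR) with Mus musculus as the target, in the maximal electroshock model, with a stated time of 30 min (a lower number here means that less compound is needed, a higher number that more compound is needed for the effect), compound 1 gives 81.3 mg/kg. Compound 2 `CN1C(=O)COCC(NC(=O)OCc2ccccc2)C1=O` carries methyl at that nitrogen, and in this assay compound 2 gives 68.8 mg/kg. Compound 3 `O=C(NC1COCC(=O)N(Cc2ccco2)C1=O)OCc1ccccc1` carries (furan-2-yl)methyl at the same nitrogen; in this assay compound 3 reaches only a limit, > 100 mg/kg. Among the two numbers shown, compound 2 stands nearest to compound 1, and the step of a 1.2-fold lower number from compound 1 to compound 2 (0.07 log units; within the scatter) does not set the two apart.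

Compound 4 `O=C(NC1COCC(=O)N(O)C1=O)OCc1ccccc1` has not yet been measured. It differs from compound 2 by hydroxy in place of methyl on an amide-type nitrogen in a ring. Going by the values given here, two measured steps touch this nitrogen directly: a 1.2-fold lower number from compound 1 to compound 2 (0.07 log units; within the scatter), and an at least 1.2-fold higher number from compound 1 to compound 3 (0.08 log units; that floor lies within the scatter), which ran into (the limit of > 100 mg/kg in this assay, at which 1 of the 3 values shown sits). The step of an at least 1.4-fold higher number from compound 2 to compound 3 (0.16 log units; that floor lies within the scatter) likewise ended at that limit. A group of one heavy atom at this nitrogen has so far moved the number only within the scatter, while the larger group pushed the value to the limit. The expectation for compound 4 in this assay is therefore a step of a 1.1-fold higher number from compound 2 to compound 4 (0.04 log units; within the scatter) that stays within the scatter. Compound 4 is estimated at 75 mg/kg, within a range from 40 mg/kg to 140 mg/kg.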

Compound 4, dose for half-maximal effect: 93.8 mg/kg
For compound 4 the middle estimate is 1.3-fold (0.10 log units) below the measured one; the range from low to high includes it.
By their numbers in this assay, from the lowest: compounds 2, 1 and 4 (each within the scatter of the next). At a limit, above all of these: compound 3.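

Going by these compounds alone, with hydroxy, a group carrying a hydrogen-bond donor and a hydrogen-bond acceptor now sits on this amide-type nitrogen for the first time, where methyl had neither, and the heavy-atom count of the group stays the same. In this assay this change gives a 1.4-fold higher number from compound 2 to compound 4 (0.13 log units; within the scatter), and the change from hydrogen to hydroxy gives a 1.2-fold higher number from compound 1 to compound 4 (0.06 log units; within the scatter), so compounds 1, 2 and 4 cannot be told apart in this read-out, and oxygen on this nitrogen has so far done no more than carbon or hydrogen there. Compound 3 remains at a limit. The step of an at least 1.0-fold lower number from compound 3 to compound 4 (0.02 log units; that floor lies within the scatter) starts from that limit: the limit of > 100 mg/kg in this assay, at which 1 of the 4 values shown sits.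

On these data alone, what stays open is whether any group on this nitrogen can move the number beyond the scatter, since every readable step here stays within it. An ethyl group or a longer chain, an amine or a carboxylic acid carried on a short chain would show whether size or such a group at this position changes the picture, and whether the furan-2-yl ring in compound 3 matters at all.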